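Amino to dimethylamino on the pendant phenyl ring

The compounds below may be only part of what the source reports. "The series", "measured", "known", "first", "only" and "open" are said of these compounds alone.

Of the compounds shown here, three built on one shared core have been measured in an assay for binding affinity to dual specificity mitogen-activated protein kinase kinase 4 (Homo sapiens), read by KINOMEscan, tested at 100 nM; on this read-out higher numbers stand for a weaker effect at the one concentration tested and lower numbers for a stronger effect. Compound 1 `CCCS(=O)(=O)Nc1ccc(F)c(C(=O)c2n[nH]c3ncc(-c4ccccc4O)cc23)c1F` gives 9%. Compound 2 `CCCS(=O)(=O)Nc1ccc(F)c(C(=O)c2n[nH]c3ncc(-c4ccc(O)cc4)cc23)c1F` gives 0.75%, and compound 3 `CCCS(=O)(=O)Nc1ccc(F)c(C(=O)c2n[nH]c3ncc(-c4cccc(N)c4)cc23)c1F` gives 1.6%. Compound 3 holds the second highest of the three numbers: its nearest neighbour is compound 2, with a number 0.9 percentage points higher from compound 2 to compound 3 (within the scatter), and its furthest is compound 1, with a number 7.4 percentage points lower from compound 1 to compound 3 (within the scatter), so every measured pair, including a number 8.3 percentage points lower from compound 1 to compound 2 (within the scatter), lies within the scatter of repeated measurements.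

Compound 4 `CCCS(=O)(=O)Nc1ccc(F)c(C(=O)c2n[nH]c3ncc(-c4cccc(N(C)C)c4)cc23)c1F` has not yet been measured. It differs from compound 3 in a single place: dimethylamino in place of amino on an aromatic carbon. The group that leaves and the group that enters both sit on an aromatic carbon of a six-membered aromatic ring of carbon only, meta to a large group.

For the measured compounds named here, no measured step bears directly on this change. The steps that exist exchange one substituted phenyl ring for another, and all of them stayed within the scatter, so there is no basis for expecting a step beyond it here. Compound 4 is therefore estimated to give 3%, with a range from 0.3% to 20%. The expected step, a number 1.4 percentage points higher from compound 3 to compound 4 (within the scatter), is one that stays within the scatter.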

Compound 4, a percentage reported as activity, at one concentration (the size of the read-out at that concentration, not a potency): 26%
Beside the measured number, compound 4's estimate is 23 percentage points below it, and the stated range ends below it.
By their numbers in this assay, from the lowest: compounds 2, 3 and 1 (each within the scatter of the next); then compound 4.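

In this assay the step of a number 24.4 percentage points higher from compound 3 to compound 4 (beyond the scatter) lies beyond the scatter, and it comes from a change confined to one group on the pendant phenyl ring: amino, with 1 heavy atom and 1 hydrogen-bond donor, gives way to dimethylamino, with 3 heavy atoms and 0 hydrogen-bond donors. For the compounds shown here, the steps of a number 25.3 percentage points higher from compound 2 to compound 4 (beyond the scatter) and a number 17 percentage points higher from compound 1 to compound 4 (beyond the scatter) also lie beyond the scatter, so compound 4 stands apart from all three earlier compounds, whereas the exchanges among those three had stayed within it; this position therefore does respond to the substituent, and the earlier compounds gave no sign of that. Nothing available accounts for this shift.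

The compounds shown leave open whether the shift follows the two added carbons or the missing nitrogen hydrogen, a question that a methylamino group, an acetamide or a methoxy group at the same place could help to separate. They also leave open how a larger group such as a pyrrolidine or a morpholine would read, and whether dimethylamino would behave the same way elsewhere on the ring.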